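A few compounds are considered here, and "the series" means these few. Any claim that something is new, unique, unknown or untested is made for them only; others in the source may bear on it.

Four close relatives of one shared core were compared in a functional assay on HCT-116 cells (Homo sapiens) for inhibition, read by MTT assay, with a stated time of 72 h; on this read-out higher numbers stand for weaker inhibition and lower numbers for stronger inhibition. Compound 1, `COc1cc2c(Oc3ccc(NC(=O)c4nn(-c5ccccc5C)cc(C)c4=O)cc3F)ccnc2cc1OCCCC(=O)NO`, carries a methyl on the aromatic ring at one end of the molecule; in this assay compound 1 gives 2040 nM. Compound 3, `COc1cc2c(Oc3ccc(NC(=O)c4nn(-c5ccccc5)cc(C)c4=O)cc3F)ccnc2cc1OCCCC(=O)NO`, differs from it in a single place: hydrogen in place of methyl on an aromatic carbon. In this assay compound 3 gives 660 nM. That change brings a 3.1-fold lower number from compound 1 to compound 3 (0.49 log units; beyond the scatter), so within this pair the unsubstituted phenyl compound is the stronger inhibitor.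

Compound 2, `COc1cc2c(Oc3ccc(NC(=O)c4nn(-c5ccccc5C)cc(C)c4=O)cc3)ccnc2cc1OCCCCCCC(=O)NO`, belongs to a second core; the difference between the two cores is not broken down here. In this assay compound 2 gives 660 nM, the same at the digits shown as compound 3, and the two lie within the usual scatter of each other.

Compound 4, `COc1cc2c(Oc3ccc(NC(=O)c4nn(-c5ccccc5)cc(C)c4=O)cc3)ccnc2cc1OCCCCCCC(=O)NO`, has not yet been measured. It stands to compound 2 as compound 3 stands to compound 1: hydrogen in place of methyl on an aromatic carbon. The place of the change reads the same in both pairs, on an aromatic carbon of a six-membered aromatic ring of carbon only, ortho to a large group, so this is the same change carried over to the second core. Among the compounds with values here, because the single measured example gave a 3.1-fold lower number from compound 1 to compound 3 (0.49 log units; beyond the scatter), the same change on compound 2 is expected to lower the number again, though one example is a thin basis and the step may come out smaller. The step from compound 2 to compound 4 is estimated at a 2.0-fold lower number from compound 2 to compound 4 (0.30 log units; within the scatter). Compound 4 is therefore expected to give 330 nM, with a likely range from 150 nM to 700 nM.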

Compound 4, half-maximal inhibitory concentration: 150 nM
The estimate for compound 4 lay 2.2-fold (0.34 log units) above the measured number, within the range that was stated.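

In this assay, going from 2-methylphenyl to phenyl on the second core brings a 4.4-fold lower number from compound 2 to compound 4 (0.64 log units; beyond the scatter), so the change that lowered the number on the first core lowers it here too. Set side by side, the two steps point the same way and do not differ in size by more than repeated measurements would: the same change on two cores in this assay, a 3.1-fold lower number (0.49 log units; beyond the scatter) from compound 1 to compound 3 and a 4.4-fold lower number (0.64 log units; beyond the scatter) from compound 2 to compound 4, 1.4-fold (0.15 log units) apart, within the scatter of two such steps. This shows that the change carried over between these two cores in this one cell assay, but two pairs are a small sample, so it does not show that the change would carry over to every core in the series, and it does not explain why removing the methyl lowers the number.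

The two cores differ both in the fluorine on the central ring and in the length of the chain that ends in the hydroxamic acid, and the compounds shown do not separate what each of these differences contributes. They also leave open how other groups in place of the methyl, such as chlorine or methoxy, would behave, and what a carboxylic acid in place of the hydroxamic acid would do to the number.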